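Two Methyls or One on the Sulfur-Linked Ring

This account rests on a few compounds, and the source may have more. Where it says the series, first, only, none or still open, it means among the compounds named here.

Measured compounds:
compound 1, `Cc1cc(C)cc(SCc2ccc(/C=C/C(=O)Nc3ccccc3N)cc2)c1`: 8.61%
compound 2, `Nc1ccccc1NC(=O)c1ccc(CSc2cccc(F)c2)cc1`: 18.6%

In a functional assay on SMMC-7721 cells (Homo sapiens) for inhibition, read by CCK-8 assay, with a stated time of 72 h, tested at 2 uM (on this read-out higher numbers stand for more inhibition of growth at the one concentration tested and lower numbers for less inhibition of growth), compound 1 gives 8.61%. Compound 2 gives 18.6%, and the gap between the two numbers lies within the usual scatter of this measurement, so neither compound can be set apart from the other; both show only weak inhibition at the concentration used.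

Compound 3, `Cc1ccc(SCc2ccc(/C=C/C(=O)Nc3ccccc3N)cc2)cc1`, has not yet been measured. It differs from compound 1 in one place: 4-methylphenyl in place of 3,5-dimethylphenyl on a sulfur. Among the measured compounds shown here, no pair of measured compounds shows what such a change does, so the data give no direct guide. Since both known numbers are low and indistinguishable, the step is expected to be small, not beyond the scatter, with no clear direction: a number 1.4 percentage points higher from compound 1 to compound 3 (within the scatter). Compound 3 is therefore estimated to give 10% in this assay, with a likely range from 0% to 22%.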

Compound 3, percent growth inhibition at one concentration: 22%
Compound 3: the middle estimate sits 12 percentage points below what was measured; the measured number falls inside the stated range.
By their numbers in this assay, from the lowest: compounds 1, 2 and 3 (each within the scatter of the next, the first and the last beyond it).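

In this assay, the group on the sulfur proves able to shift the result: 4-methylphenyl in place of 3,5-dimethylphenyl gives a number 13.4 percentage points higher from compound 1 to compound 3 (beyond the scatter), a modest step but the first here that can be read as a real change. Both groups are carbon-only aromatic rings with no net charge, so a small edit between closely similar groups at this position is enough to move the number. No available data explain why the number moves.

The swap changes both how many methyl groups the ring carries and where they sit, so these compounds cannot separate the two effects. Also open, going by these compounds, is how the number would respond to an amine or a carboxylic acid on this ring in place of the methyl.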